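The source may report more compounds than this note shows. Statements on the series, on what has been measured and on what is new or still open speak of the compounds shown alone.

Measured compounds in an ADME assay on HepG2 cells (Homo sapiens) for cytotoxicity, read by luminescence, CellTiter-Glo and ATP content, with a stated time of 72 h; on this read-out lower numbers stand for an effect already at smaller amounts and higher numbers for an effect only at larger amounts of compound:
Compound 1, `c1ccc(Oc2ccc3c(NCCCNCc4ccco4)ccnc3c2)cc1`, gives 15200 nM.
Compound 2, `COc1cccc(CNCCCNc2ccnc3cc(Oc4ccccc4)ccc23)c1O`, gives 6800 nM.
Compound 3, `c1ccc(Cc2ccc3c(NCCCNCc4ccco4)ccnc3c2)cc1`, gives 16000 nM.

Of the three numbers, compound 2 has the lowest; the step of a 2.2-fold lower number from compound 1 to compound 2 (0.35 log units; beyond the scatter) lies beyond the scatter, and compound 3 sits further off still, so compound 2 is the one acting at the smallest amount in this set. Among the compounds with values here, the other measured step, a 1.1-fold higher number from compound 1 to compound 3 (0.02 log units; within the scatter), is the only exchange of the side group on the shared core that has been followed so far.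

Compound 4, `COc1cccc(CNCCCNc2ccnc3cc(Cc4cc(C)cc(C)c4)ccc23)c1O`, has not yet been measured. Relative to compound 2 the change is 3,5-dimethylbenzyl in place of phenoxy on an aromatic carbon. The step that bears on it is a 1.1-fold higher number from compound 1 to compound 3 (0.02 log units; within the scatter), since benzyl in place of phenoxy on an aromatic carbon is the same kind of exchange on the same core, and it stayed within the scatter. Within the data shown here, no measured compound carries a 3,5-dimethylbenzyl, so the methyl groups of that group are not covered by any step. On this basis no step beyond the scatter is expected in this assay for compound 4; its number is estimated at 7000 nM, with a range from 3000 nM to 16000 nM. That estimate corresponds to an expected step of a 1.0-fold higher number from compound 2 to compound 4 (0.01 log units; within the scatter).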

Compound 4, half-maximal effective concentration: 2680 nM
Compound 4: middle estimate off by 2.6-fold (0.42 log units), on the high side; the measured number lies below the stated range.
By their numbers in this assay, from the lowest: compound 4; then compound 2; then compounds 1 and 3 (each within the scatter of the next).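

In this assay, within the data shown here, the position that carries phenoxy is no longer silent: a 2.5-fold lower number from compound 2 to compound 4 (0.40 log units; beyond the scatter) is a step beyond the scatter, whereas the only earlier exchange here, a 1.1-fold higher number from compound 1 to compound 3 (0.02 log units; within the scatter), stayed within it. The two steps are not a clean pair, as the entering group is 3,5-dimethylbenzyl in one and benzyl in the other, and the chain carries 2-hydroxy-3-methoxyphenyl in one and furan-2-yl in the other, so a change at this aromatic carbon can move the number in at least one setting of the series, with the oxygen-containing phenoxy giving way to an all-carbon group of 9 heavy atoms. Nothing available explains why this step lies beyond the scatter while the earlier one does not.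

The compounds shown leave open whether the two methyl groups account for the step or whether the side group on the chain decides how this position responds, as plain benzyl appears only with furan-2-yl. Also open, as far as these compounds go, is how a chloro or trifluoromethyl group in place of those methyl groups, or a longer chain between the two amine nitrogens, would read in this assay.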